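The source may report more compounds than this note shows. Statements on the series, on what has been measured and on what is new or still open speak of the compounds shown alone.

Compound 1 `Cc1ccc(NC(=O)CCN(Cc2ccc(C(=O)NO)cc2)C(=O)c2cc(C)cc(C)c2)cc1` gives 210 nM
Compound 2 `Cc1cc(C)cc(C(=O)N(CCC(=O)NCc2ccccc2)Cc2ccc(C(=O)NO)cc2)c1` gives 1390 nM
Compound 3 `CN(C)c1ccc(C(=O)N(CCC(=O)NCc2ccc(Cl)cc2)Cc2ccc(C(=O)NO)cc2)cc1` gives 310 nM

All three values come from a functional assay on IMR-32 cells (Homo sapiens) for antiproliferative activity, with a stated time of 72 h; a higher number here means a weaker inhibitor, a lower number a stronger inhibitor. Compound 2, at 1390 nM, has the highest number of the three, and its gaps to compound 3 and compound 1 both lie beyond the scatter. The next compound, compound 4 `Cc1ccc(C(=O)N(CCC(=O)NCc2ccccc2)Cc2ccc(C(=O)NO)cc2)cc1`, carries 4-methylphenyl in place of 3,5-dimethylphenyl on a carbonyl carbon, a change counted as 4-methylphenyl in place of 3,5-dimethylphenyl on a carbonyl carbon. Going by the values given here, the only measured step between compounds differing in one place is a 6.6-fold higher number from compound 1 to compound 2 (0.82 log units; beyond the scatter). It puts benzyl in place of 4-methylphenyl on an amide-type nitrogen, a different place, so it does not test this change. Compound 3, at 310 nM, differs from compound 2 in more than one place and cannot isolate it either. Among the compounds with values here, with no measured step at this carbonyl carbon, no step beyond the scatter is expected in this assay. The expected step is a 1.4-fold lower number from compound 2 to compound 4 (0.14 log units; within the scatter). The estimated value of compound 4 is 1000 nM, with an expected range of 400 nM to 2500 nM.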

Compound 4, half-maximal inhibitory concentration: 630 nM
For compound 4 the middle estimate is 1.6-fold (0.20 log units) above the measured one; low and high end bracket the measured number.
By their numbers in this assay, from the lowest: compounds 1 and 3 (each within the scatter of the next); then compound 4; then compound 2.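

In this assay, the group on the carbonyl carbon now has a measured step of its own: a 2.2-fold lower number from compound 2 to compound 4 (0.34 log units; beyond the scatter). The earlier step changed only the group on an amide-type nitrogen, so this result adds a second place where a single change moves the number beyond the scatter, with 4-methylphenyl giving the lower number of the pair when benzyl sits on the other amide. No measured evidence shown here bears on the reason for this step.

As far as these compounds go, whether the same change gives a similar step with the 4-methylphenyl amide of compound 1 remains open. Also open, from the compounds shown here alone, is how this carbonyl position would respond to an unsubstituted phenyl ring, or to a ring carrying a carboxylic acid or a methoxy group.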